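A few compounds are considered here, and "the series" means these few. Any claim that something is new, unique, unknown or untested is made for them only; others in the source may bear on it.

Among the compounds with values here, in a functional assay on prostate cells (Homo sapiens) for antiproliferative activity (on this read-out lower numbers stand for stronger inhibition of growth and higher numbers for weaker inhibition of growth), compound 1 `Cc1cn2c(/C=N/NC(=N)N)c(-c3cccnc3)nc2s1` gives 24500 nM, the lower of the two numbers measured so far; compound 2 `N=C(N)N/N=C/c1c(-c2cccnc2)nc2sc(Cl)cn12` gives 28200 nM, and the step of a 1.2-fold higher number from compound 1 to compound 2 (0.06 log units; within the scatter) stays within the scatter. That step exchanges a small group elsewhere on the shared core and says nothing about exchanging one pyridinyl for another. Compound 3 `Cc1cn2c(/C=N/NC(=N)N)c(-c3ccccn3)nc2s1` differs from compound 1 by pyridin-2-yl in place of pyridin-3-yl on an aromatic carbon. Within the data shown here, no measured step covers this kind of change, so the expectation rests only on compound 1 as the starting point. Compound 3 is expected to give 25000 nM, within 10000 nM to 65000 nM. The expected step of a 1.0-fold higher number from compound 1 to compound 3 (0.01 log units; within the scatter) is therefore none beyond the scatter.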

Compound 3, concentration for total growth inhibition: 39800 nM
Beside the measured number, compound 3's estimate is 1.6-fold (0.20 log units) below it; low and high end bracket the measured number.
By their numbers in this assay, from the lowest: compounds 1, 2 and 3 (each within the scatter of the next).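

In this assay the exchange of pyridin-3-yl for pyridin-2-yl on this aromatic carbon gives a 1.6-fold higher number from compound 1 to compound 3 (0.21 log units; within the scatter) and so stays within the usual scatter. At this position, then, the two pyridinyl groups cannot be told apart on this read-out, whereas the earlier step concerned only a small group elsewhere on the shared core. Nothing available explains this result.

Still open, from the compounds shown here alone, is whether pyridin-4-yl would behave the same way here. Going by these compounds, it is also open whether a plain phenyl ring or an amine at this position would shift the number beyond the scatter.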